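The source may report more compounds than this note shows. Statements on the series, on what has been measured and on what is new or still open speak of the compounds shown alone.

Compound 1 `CC(C)CCc1ccc2c(NCCCNCc3ccco3)ccnc2c1` was examined in a physicochemical assay for solubility, with a stated time of 18 h, at pH 7.4 (a lower number here means a less soluble compound, a higher number a more soluble compound), where compound 1 gives 4200 nM. Two neighbours share its core. Compound 2 `COc1cccc(CNCCCNc2ccnc3cc(CCC(C)C)ccc23)c1O` carries a 2-hydroxy-3-methoxyphenyl in place of the furan-2-yl on a saturated chain carbon bound to an amine nitrogen, and in this assay compound 2 gives 4200 nM. Compound 3 `FC(F)(F)c1cccc(Cc2ccc3c(NCCCNCc4ccco4)ccnc3c2)c1` carries a 3-(trifluoromethyl)phenyl in place of the isobutyl on a saturated chain carbon bound to an aromatic carbon, and in this assay compound 3 gives 4200 nM. Compound 1 therefore stands level with both, with no change at the digits printed from compound 1 to compound 2 (within the scatter) and no change at the digits printed from compound 1 to compound 3 (within the scatter).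

Compound 4 `c1coc(CNCCCNc2ccnc3cc(-c4cccc5ccccc45)ccc23)c1` has not yet been measured. It differs from compound 1 in one place: naphthalen-1-yl in place of isopentyl on an aromatic carbon. The nearest guide is the step from compound 1 to compound 3, which also swapped a small saturated group for a ring-bearing one and gave no change at the digits printed from compound 1 to compound 3 (within the scatter). The step from compound 1 to compound 2 touched a different part of the molecule and likewise gave no change at the digits printed from compound 1 to compound 2 (within the scatter). The naphthalen-1-yl group is larger than either of those newcomers, so a small downward move in this assay is expected, though it may stay within the scatter. The expected step is a 2.1-fold lower number from compound 1 to compound 4 (0.32 log units; beyond the scatter). Compound 4 is estimated to give 2000 nM, within a range from 600 nM to 4500 nM.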

Compound 4, solubility: 32000 nM
Compound 4: the middle estimate sits 16-fold (1.20 log units) below what was measured; measured number outside the range, above it.
By their numbers in this assay, from the lowest: compounds 1, 2 and 3 (each within the scatter of the next); then compound 4.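

In this assay, the site that held the isopentyl group in compound 1 is not indifferent to what it carries: naphthalen-1-yl in place of isopentyl, with 10 heavy atoms replacing 5 and two aromatic rings of carbon only where there was no ring, gives a 7.6-fold higher number from compound 1 to compound 4 (0.88 log units; beyond the scatter) and moves beyond the scatter. The earlier change in this part of the molecule gave no change at the digits printed from compound 1 to compound 3 (within the scatter), but there the new ring stayed attached through a saturated chain carbon, whereas in compound 4 the ring system sits directly on the aromatic carbon, so adding an aromatic ring here does not by itself settle the outcome. The direction also matters, since the larger group comes with a higher number, yet nothing shown accounts for this rise.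

As far as these compounds go, it remains open whether the fused second ring, the direct attachment or the particular naphthalen-1-yl shape drives the step, and a plain phenyl or a naphthalen-2-yl group on the same aromatic carbon would help separate these. Also open, from the compounds shown here alone, is whether the step would hold with the 2-hydroxy-3-methoxyphenyl group of compound 2 in place of the furan-2-yl.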